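Ethyl to methyl on the shared core: clearance notes

The compounds below may be only part of what the source reports. "The series", "measured", "known", "first", "only" and "open" are said of these compounds alone.

Compound 1, `CC[C@H]1c2cc(Cl)ccc2C(=O)N1c1cncc2c1CCC[C@H]2NC(C)=O`, in an ADME assay on microsomes from liver (Mus musculus) for metabolic stability, read by LC-MS, using NADPH, with stated times of 10 min and 30 min (on this read-out higher numbers stand for fast clearance and lower numbers for slow clearance), gives < 20.2 mL/min/kg, which is a limit of the assay and not a number.
Compound 2, `CCC(=O)N[C@@H]1CCCc2c1cncc2N1C(=O)c2ccc(Cl)cc2[C@@H]1CC`, in this assay gives < 20.2 mL/min/kg, again a limit.
Compound 3, `CC[C@@H]1c2cc(Cl)ccc2C(=O)N1c1cncc2c1CCC[C@H]2NC(C)=O`, in this assay gives < 20.2 mL/min/kg, again a limit.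

Compound 1 therefore stands at the limit in this assay, with no number of its own. Both measured steps that start from it are unreadable because of the limit of < 20.2 mL/min/kg in this assay, at which 3 of the 3 values shown sit. The step that the two limits leave unreadable from compound 1 to compound 2 puts a methyl in place of hydrogen on a saturated chain carbon bound to a carbonyl carbon. The step that the two limits leave unreadable from compound 1 to compound 3 rests on (the fact that compounds 1 and 3 differ only in the configuration as drawn), so it tells nothing about a change of atoms.

Compound 4, `CC(=O)N[C@@H]1CCCc2c1cncc2N1C(=O)c2ccc(Cl)cc2[C@@H]1C`, differs from compound 1 by hydrogen in place of methyl on a saturated chain carbon bound to a saturated ring carbon. For the measured compounds named here, no measured step covers this place; the step to compound 2 is the nearest kind of change, a methyl lost or gained, and its size could not be read. Going by the values given here, nothing among the measured values points to clearance leaving the low region. The expected size of the step is a step that the limit leaves unreadable from compound 1 to compound 4, which is taken as nothing beyond the scatter. Compound 4 is expected to give about 12 mL/min/kg in this assay, with a range from 5 mL/min/kg to 25 mL/min/kg, most likely reported again only as a limit.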

Compound 4, clearance: < 20.2 mL/min/kg
Compound 4 ended at the assay's limit; the forecaster's own chance of this, stated with the estimate: 80%; the middle value lies beyond the limit too.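

In this assay compound 4 gives < 20.2 mL/min/kg, a limit and not a number. No new step can be read between compound 1 and compound 4, because the result adds one more value at the same limit: the limit of < 20.2 mL/min/kg in this assay, at which 4 of the 4 values shown sit.

The compounds shown leave open whether the changes in chain length or configuration on the shared core alter clearance at all.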